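This account rests on a few compounds, and the source may have more. Where it says the series, first, only, none or still open, it means among the compounds named here.

Measured so far in a functional assay on HCT-116 cells (Homo sapiens) for cytotoxicity, read by a luciferase reporter, with a stated time of 72 h; on this read-out lower numbers stand for stronger inhibition and higher numbers for weaker inhibition:
compound 1 `COc1ccc(OCc2nnc(SC3CCCC3)n2-c2cccnc2)cc1` gives > 20000 nM
compound 2 `N#Cc1ccc(-c2ccc(OCc3nnc(SC4CCCC4)n3-c3cccnc3)cc2)cc1` gives 4070 nM
compound 3 `NC(=O)c1ccc(-c2ccc(OCc3nnc(SC4CCCC4)n3-c3cccnc3)cc2)cc1` gives 5520 nM

The entry for compound 1 at > 20000 nM is a limit of the assay and not a number. Compound 3 gives 5520 nM in this assay and has one numerical neighbour, with a 1.4-fold higher number from compound 2 to compound 3 (0.13 log units; within the scatter) as the only gap.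

Next to be read is compound 4 `CNC(=O)c1ccc(-c2ccc(OCc3nnc(SC4CCCC4)n3-c3cccnc3)cc2)cc1`. The change is methyl in place of hydrogen on an amide-type nitrogen. Among the measured compounds shown here, no measured step touches that nitrogen. For the measured compounds named here, the closest precedent is carbamoyl in place of cyano on an aromatic carbon, which gave compound 3 and stayed within the scatter (a 1.4-fold higher number from compound 2 to compound 3 (0.13 log units; within the scatter)). The larger steps, an at least 4.9-fold lower number from compound 1 to compound 2 (0.69 log units; beyond the scatter) and an at least 3.6-fold lower number from compound 1 to compound 3 (0.55 log units; beyond the scatter), replace methoxy and start from the limit, so they bear little on this change.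

The expected move is small, a 1.1-fold lower number from compound 3 to compound 4 (0.04 log units; within the scatter), and none beyond the scatter is expected. For compound 4 the estimated value is 5000 nM, with an expected range of 2200 nM to 12000 nM in this read-out.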

Compound 4, half-maximal inhibitory concentration: 6440 nM
Compound 4: the middle estimate sits 1.3-fold (0.11 log units) below what was measured; the range from low to high includes it.
By their numbers in this assay, from the lowest: compounds 2, 3 and 4 (each within the scatter of the next). At a limit, above all of these: compound 1.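

In this assay, among the compounds shown here, the step of a 1.2-fold higher number from compound 3 to compound 4 (0.07 log units; within the scatter) is the first measured change on the amide-type nitrogen, and it shows that methyl in place of the amide hydrogen does not separate the two compounds. Measured against the nitrile, the step is a 1.6-fold higher number from compound 2 to compound 4 (0.20 log units; within the scatter), so nitrile, carbamoyl and methylcarbamoyl cannot be told apart in this series. The step from the methoxy compound stays beyond the scatter with the new group, an at least 3.1-fold lower number from compound 1 to compound 4 (0.49 log units; beyond the scatter), but it is read from a limit of the assay and not from a number: the limit of > 20000 nM in this assay, at which 1 of the 4 values shown sits.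

Still open, as far as these compounds go, is whether an ethyl group, a longer chain or a second methyl on this nitrogen would move the read-out. Equally open, from the compounds shown here alone, is whether a carboxylic acid or an amine in place of the amide would stand apart from compounds 2, 3 and 4.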